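Series notes: replacing 3,4-dimethylphenyl with 2,5-dichlorophenyl

This account rests on a few compounds, and the source may have more. Where it says the series, first, only, none or still open, it means among the compounds named here.

Measured in a functional assay on Jurkat cells (Homo sapiens); a lower number here means a stronger inhibitor, a higher number a weaker inhibitor:
- compound 1 `Cc1ccc(CNC(=O)C(=O)N[C@@H](C)C(=O)N[C@@H](CC(=O)O)C(=O)COc2c(F)c(F)cc(F)c2F)cc1`: 50 nM
- compound 2 `C[C@H](NC(=O)C(=O)NCc1cccc(F)c1)C(=O)N[C@@H](CC(=O)O)C(=O)COc1c(F)c(F)cc(F)c1F`: 106 nM
- compound 3 `Cc1ccc(CNC(=O)C(=O)N[C@@H](C)C(=O)N[C@@H](CC(=O)O)C(=O)COc2c(F)c(F)cc(F)c2F)cc1C`: > 10000 nM

Compound 3 gives > 10000 nM in this assay, which is a limit of the assay and not a number.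

Compound 4 `C[C@H](NC(=O)C(=O)NCc1cc(Cl)ccc1Cl)C(=O)N[C@@H](CC(=O)O)C(=O)COc1c(F)c(F)cc(F)c1F` differs from compound 3 in one place: 2,5-dichlorophenyl in place of 3,4-dimethylphenyl on a saturated chain carbon bound to an amide-type nitrogen. This puts 2,5-dichlorophenyl in place of 3,4-dimethylphenyl on a saturated chain carbon bound to an amide-type nitrogen.

Two large measured steps end at compound 3 and point to a higher number: an at least 200-fold higher number from compound 1 to compound 3 (2.30 log units; beyond the scatter) and an at least 94-fold higher number from compound 2 to compound 3 (1.97 log units; beyond the scatter). A third step, a 2.1-fold higher number from compound 1 to compound 2 (0.33 log units; beyond the scatter), is only modest. Among the measured compounds shown here, no compound with chlorine on the ring has been measured, so the effect of the entering group remains open and the expectation is loose.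

Compound 4 no longer carries the 3,4-dimethylphenyl group, so its number is expected to return toward compound 1 at 50 nM and compound 2 at 106 nM. A large move to a lower number is expected, estimated as an at least 33-fold lower number from compound 3 to compound 4 (1.52 log units; beyond the scatter). For compound 4 the estimated value is 300 nM, with an expected range from 40 nM to 4000 nM.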

Compound 4, half-maximal inhibitory concentration: 4.3 nM
Estimate against measurement, compound 4: 70-fold (1.84 log units) above, and the stated range ends above it.
By their numbers in this assay, from the lowest: compound 4; then compound 1; then compound 2. At a limit, above all of these: compound 3.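

In this assay, the place on a saturated chain carbon bound to an amide-type nitrogen can carry a ring with two substituents and still improve on the singly substituted rings: 2,5-dichlorophenyl gives a 12-fold lower number from compound 1 to compound 4 (1.07 log units; beyond the scatter) and a 25-fold lower number from compound 2 to compound 4 (1.39 log units; beyond the scatter). Two substituents on the ring therefore do not in themselves bring the loss seen with 3,4-dimethylphenyl, since the exchange of that group for 2,5-dichlorophenyl gives an at least 2300-fold lower number from compound 3 to compound 4 (3.36 log units; beyond the scatter), so the identity of the substituents, their arrangement or both must decide the outcome here. The size of that step has one open end, as compound 3 stands at a limit of the assay and not at a number: the limit of > 10000 nM in this assay, at which 1 of the 4 values shown sits.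

The compounds shown do not separate the chlorine atoms from their arrangement on the ring, and a pair made up of 3,4-dichlorophenyl and 2,5-dimethylphenyl would settle that point. From the compounds shown here alone, it also remains open whether a single chlorine, as in a 2-chlorophenyl or 3-chlorophenyl group, is enough to give the lower number seen with compound 4.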